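Aryl Swap at the Ring Nitrogen: Cytotoxicity Expectation

The source may report more compounds than this note shows. Statements on the series, on what has been measured and on what is new or still open speak of the compounds shown alone.

Compound 1 `CNC(=O)c1cc(Oc2ccc(NC(=O)c3nn(-c4ccccc4C(F)(F)F)c(=O)cc3C)cc2F)ccn1`: > 40000 nM
Compound 2 `CNC(=O)c1cc(Oc2ccc(NC(=O)c3nn(-c4ccccc4OC(F)(F)F)c(=O)cc3C)cc2F)ccn1`: > 40000 nM

In a functional assay on HepG2 cells (Homo sapiens) for cytotoxicity, read by MTT assay, with a stated time of 72 h (a lower number here means a stronger inhibitor, a higher number a weaker inhibitor), compound 1 gives > 40000 nM, a limit of the assay and not a number. In this assay compound 2 gives > 40000 nM, again a limit rather than a measured number. Compound 2 therefore stands at the edge of what this assay reports, and the step that the two limits leave unreadable from compound 1 to compound 2 stays unreadable due to the limit of > 40000 nM in this assay, at which 2 of the 2 values shown sit.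

Compound 3 `CNC(=O)c1cc(Oc2ccc(NC(=O)c3nn(-c4ccc(C)cc4)c(=O)cc3C)cc2F)ccn1` has not yet been measured in this assay. It differs from compound 2 by 4-methylphenyl in place of 2-(trifluoromethoxy)phenyl on an aromatic nitrogen. For the measured compounds named here, no measured step bears directly on this change, since the only step known is unreadable. On the numbers shown, compound 3 is expected to sit at about 40000 nM, in a range from 15000 nM to 100000 nM, and is most likely to be reported as a limit once more. The step of a number no higher from compound 2 to compound 3 (the limit leaves the size open) is accordingly expected to show no change beyond the scatter.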

Compound 3, half-maximal inhibitory concentration: 10600 nM
Compound 3: middle estimate off by 3.8-fold (0.58 log units), on the high side; the whole stated range lies above it.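

In this assay, 4-methylphenyl in place of 2-(trifluoromethoxy)phenyl on the aromatic nitrogen gives an at least 3.7-fold lower number from compound 2 to compound 3 (0.57 log units; beyond the scatter), and 4-methylphenyl in place of 2-(trifluoromethyl)phenyl gives an at least 3.7-fold lower number from compound 1 to compound 3 (0.57 log units; beyond the scatter). The aryl group on this nitrogen can therefore move the read-out into the range the assay reports as a number, which the two earlier compounds could not show. For compound 1 and compound 2 the reading is a limit and not a number, so both steps give only a floor on the size of the change, and the step between those two compounds cannot be read: the limit of > 40000 nM in this assay, at which 2 of the 3 values shown sit.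

On these data alone, it remains open whether the lower number goes with the methyl group itself or with where it stands, a question that 2-methylphenyl and 4-(trifluoromethyl)phenyl would separate. As far as these compounds go, how an unsubstituted phenyl or a 4-aminophenyl on the same nitrogen would read is also open.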